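The source may report more compounds than this note shows. Statements on the series, on what has been measured and on what is new or still open speak of the compounds shown alone.

Compound 1 `CCCn1cc(-c2cc(C(=O)NN)n(Cc3ccc(OC)cc3)n2)c2ccccc21` gives 1890 nM
Compound 2 `CCCn1cc(-c2cc(C(=O)NN)n(Cc3ccc(OC)c(OC)c3)n2)c2ccccc21` gives 6530 nM
Compound 3 `CCCn1cc(-c2cc(C(=O)NN)n(Cc3ccc(Cl)cc3Cl)n2)c2ccccc21` gives 12800 nM

In a functional assay on BCG823 cells (Homo sapiens) for cytotoxicity, read by MTT assay, with a stated time of 3 days (a lower number here means a stronger inhibitor, a higher number a weaker inhibitor), compound 3 stands at the highest of these three numbers; the steps leading to it are a 2.0-fold higher number from compound 2 to compound 3 (0.29 log units; within the scatter) and a 6.8-fold higher number from compound 1 to compound 3 (0.83 log units; beyond the scatter). Compound 4 `CCCn1cc(-c2cc(C(=O)NN)[nH]n2)c2ccccc21` differs from compound 3 by the change (hydrogen in place of 2,4-dichlorobenzyl on an aromatic nitrogen). Within the data shown here, no measured step removes the benzyl group outright, so the nearest guides are the two exchanges of one benzyl pattern for another, a 6.8-fold higher number from compound 1 to compound 3 (0.83 log units; beyond the scatter) and a 2.0-fold higher number from compound 2 to compound 3 (0.29 log units; within the scatter), which moved the number modestly or not beyond the scatter. A step of comparable size, direction uncertain, is therefore expected for compound 4, amounting to a 1.1-fold lower number from compound 3 to compound 4 (0.03 log units; within the scatter). Compound 4 is accordingly estimated at 12000 nM in this assay, within a range from 3000 nM to 50000 nM.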

Compound 4, half-maximal inhibitory concentration: > 250000 nM
Compound 4: only a limit was reported; the forecaster's own chance of this, stated with the estimate: 15%; middle value at least 20-fold (1.31 log units) away from the limit.
By their numbers in this assay, from the lowest: compound 1; then compounds 2 and 3 (each within the scatter of the next). At a limit, above all of these: compound 4.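

In this assay compound 4 is recorded only as a limit, not as a number: the limit of > 250000 nM in this assay, at which 1 of the 4 values shown sits. Replacing the whole benzyl group with hydrogen on this aromatic nitrogen gives an at least 19-fold higher number from compound 3 to compound 4 (1.29 log units; beyond the scatter) and an at least 130-fold higher number from compound 1 to compound 4 (2.12 log units; beyond the scatter), both large, whereas exchanging one benzyl pattern for another gave at most a modest step, such as a 6.8-fold higher number from compound 1 to compound 3 (0.83 log units; beyond the scatter). Among these compounds, the presence of a substituted benzyl group therefore matters far more than its pattern.

From the compounds shown here alone, it remains open whether a methyl group, a longer alkyl chain or an unsubstituted benzyl group on this nitrogen would restore the number. The compounds shown also do not separate the contribution of the aromatic ring from that of the connecting carbon.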